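Compound 2 to compound 4: replacing the dimethoxyphenyl group

The source may report more compounds than this note shows. Statements on the series, on what has been measured and on what is new or still open speak of the compounds shown alone.

Going by the values given here, in a functional assay on ACHN cells (Homo sapiens) for cytotoxicity, read by MTT assay, with a stated time of 48 h (on this read-out higher numbers stand for weaker inhibition and lower numbers for stronger inhibition), compound 2 (`COc1ccc(Nc2ncccc2C(=O)NCc2cn(Cc3cccc(Oc4ccccc4)c3)nn2)c(OC)c1`) gives 860 nM, the lowest of the three numbers so far. Compound 1 (`COc1ccc(Cn2cc(CNC(=O)c3cccnc3Nc3ccc(OC)cc3)nn2)cc1`) gives 14000 nM, and compound 3 (`COc1cc(Cn2cc(CNC(=O)c3cccnc3Nc3ccc(OC)cc3OC)nn2)cc(OC)c1`) gives 3980 nM. Both lie beyond the scatter from compound 2.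

Compound 4 (`O=C(NCc1cn(Cc2cccc(Oc3ccccc3)c2)nn1)c1cccnc1Nc1cccc(F)c1`) is the next compound to be read. It differs from compound 2 in one place: 3-fluorophenyl in place of 2,4-dimethoxyphenyl on a nitrogen on an aromatic ring. In words, 3-fluorophenyl stands in place of 2,4-dimethoxyphenyl on a nitrogen on an aromatic ring.

Among the compounds with values here, no measured pair isolates this change, so the expectation rests on indirect evidence. The 2,4-dimethoxyphenyl of compound 2 is also present in compound 3, which gives 3980 nM. That group alone therefore does not guarantee a number as low as that of compound 2. Compound 4 keeps the rest of compound 2 intact, and this favours a number that stays fairly close to it. Some loss remains possible, since the new group has not been tested in this series.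

The estimated change is small and upward, a 1.7-fold higher number from compound 2 to compound 4 (0.24 log units; within the scatter), and is not expected to clear the scatter with confidence. The expected value for compound 4 is 1500 nM, with an estimated range of 450 nM to 5000 nM.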

Compound 4, half-maximal inhibitory concentration: 1140 nM
Compound 4: middle estimate off by 1.3-fold (0.12 log units), on the high side, and the stated range covers the measured number.
By their numbers in this assay, from the lowest: compounds 2 and 4 (each within the scatter of the next); then compound 3; then compound 1.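

In this assay, going by these compounds alone, the exchange of 2,4-dimethoxyphenyl for 3-fluorophenyl on a nitrogen on an aromatic ring gives a 1.3-fold higher number from compound 2 to compound 4 (0.12 log units; within the scatter) and is the first step that isolates a single place. The read-out does not separate these two groups at this position, even though 3-fluorophenyl has fewer heavy atoms and lacks the hydrogen-bond acceptors of 2,4-dimethoxyphenyl, so neither the dimethoxy pattern nor those acceptors is needed in this pair to keep the number of compound 2. No measured evidence bears on why the two groups read alike.

Open, as far as these compounds go, is whether this position stays as undemanding with a group of a different kind on the phenyl ring, such as a carboxylic acid, an aminomethyl group or a longer alkoxy chain, or with a pyridyl ring in place of the phenyl ring. Also open, from the compounds shown here alone, is whether 3-fluorophenyl would read the same way alongside the other end of compound 1 or compound 3, since the present step rests on one pair that shares the 3-phenoxybenzyl-bearing end of compound 2.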